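Methyl Additions on Two Related Cores at a Glutamate Receptor

The source may report more compounds than this note shows. Statements on the series, on what has been measured and on what is new or still open speak of the compounds shown alone.

Measured compounds:
Compound 1, `Cc1cccc(-c2ccc3cccnc3n2)c1`, 225 nM 
Compound 2, `Cc1ccc(-c2ccc3cccnc3n2)cc1C`, 45 nM 
Compound 3, `Cc1cccc(-c2cnc3cccnc3c2)c1`, 15700 nM 

All three were tested in a functional assay on CHO cells for antagonist activity at metabotropic glutamate receptor 5 (Rattus norvegicus), read by calcium flux; on this read-out higher numbers stand for weaker inhibition and lower numbers for stronger inhibition. Compound 1 and compound 2 share a core and differ by one change, (methyl in place of hydrogen on an aromatic carbon). That change made a 5.0-fold lower number from compound 1 to compound 2 (0.70 log units; beyond the scatter), so the added methyl group went with a stronger inhibition.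

Compound 3 is built from the same atoms as compound 1, joined differently; the difference between the two cores is not broken down here. In this assay compound 3 gives 15700 nM, the highest number of the three, well beyond the scatter from compound 1 and from compound 2.

Compound 4, `Cc1cc(C)cc(-c2cnc3cccnc3c2)c1`, has not yet been measured. It differs from compound 3 by methyl in place of hydrogen on an aromatic carbon. This is the same kind of change as that from compound 1 to compound 2, but the surroundings differ: in compound 2 the new methyl sits ortho to a methyl group and para to a large group, while in compound 4 it sits meta to a large group and meta to a methyl group. Among the measured compounds shown here, only one such step has been measured, so the expectation rests on that single example. Compound 4 is expected to show a step of about a 2.6-fold lower number from compound 3 to compound 4 (0.42 log units; beyond the scatter) in this assay, a smaller gain than the earlier one. Compound 4 is estimated at 6000 nM, with a likely range from 2000 nM to 20000 nM.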

Compound 4, half-maximal inhibitory concentration: > 30000 nM
Compound 4 was reported as a limit (the forecaster's own chance of this, stated with the estimate: 10%); middle value at least 5.0-fold (0.69 log units) away from the limit.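

In this assay compound 4 gives > 30000 nM, which is a limit of the assay and not an exact number: the limit of > 30000 nM in this assay, at which 1 of the 4 values shown sits. The new step reads an at least 1.9-fold higher number from compound 3 to compound 4 (0.28 log units; that floor lies within the scatter), so the stronger inhibition that went with the added methyl on the core of compound 1 did not carry over to the core of compound 3, and the two steps clearly differ: the same change on two cores in this assay, a 5.0-fold lower number (0.70 log units; beyond the scatter) from compound 1 to compound 2 and an at least 1.9-fold higher number (0.28 log units; that floor lies within the scatter) from compound 3 to compound 4, at least 9.5-fold (0.98 log units) apart, beyond the scatter of two such steps. This shows that the effect of this change cannot simply be transferred from one core to the other in this series, but it does not show how large the second step really is, whether it is a true loss, since its floor alone lies within the scatter, or whether the core is what matters, since the new methyl also sits in different surroundings in the two steps.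

As far as these compounds go, it remains open whether a methyl placed meta to a large group and meta to a methyl group would give the same result on the core of compound 1, which would help to separate the role of the core from that of the position. From the compounds shown here alone, it is also open how a chlorine atom or a methoxy group at that same place would behave on either core.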